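The source may hold more compounds than are shown below. What is called first, only, known or untested is meant among the compounds shown, and "the series" means these compounds.

Among the compounds with values here, in a functional assay on DU-145 cells (Homo sapiens) for cytotoxicity, read by CCK-8 assay and cell counting, with a stated time of 2 days (a lower number here means a stronger inhibitor, a higher number a weaker inhibitor), compound 2 `Oc1ccc(-c2cc(-c3ccc(Cl)cc3)nc(-c3cccnc3)c2)cc1` gives 22800 nM, the highest of the three numbers measured so far. Compound 3 `Oc1ccc(-c2cc(-c3ccc(Cl)cc3)nc(-c3cccs3)c2)cc1` gives 7660 nM, and compound 1 `Oc1ccc(-c2cc(-c3ccccc3)nc(-c3ccccc3Cl)c2)cc1` gives 2800 nM. Within the data shown here, the single one-place step among the measured compounds, a 3.0-fold lower number from compound 2 to compound 3 (0.47 log units; beyond the scatter), exchanges pyridin-3-yl for thiophen-2-yl and leaves the 4-hydroxyphenyl group untouched. Compound 4 `Oc1cccc(-c2cc(-c3ccc(Cl)cc3)nc(-c3cccnc3)c2)c1` differs from compound 2 by 3-hydroxyphenyl in place of 4-hydroxyphenyl on an aromatic carbon. Among the measured compounds shown here, no measured step exchanges 4-hydroxyphenyl for 3-hydroxyphenyl, so nothing in these data bears directly on this change; the step from compound 2 to compound 3 concerns a different part of the shared core. In the absence of any guiding step, the expected outcome is no change beyond the scatter, and compound 4 is expected to show no change at the digits printed from compound 2 to compound 4 (within the scatter). Since compound 2 gives 22800 nM, compound 4 is estimated to give 22800 nM in this assay, within a range from 8000 nM to 65000 nM.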

Compound 4, half-maximal inhibitory concentration: 26800 nM
Compound 4: the middle estimate sits 1.2-fold (0.07 log units) below what was measured, within the range that was stated.
By their numbers in this assay, from the lowest: compound 1; then compound 3; then compounds 2 and 4 (each within the scatter of the next).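

In this assay, the hydroxyl group on this aryl substituent, which sits opposite the ring nitrogen of the shared core, was moved for the first time in the compounds shown, and exchanging 4-hydroxyphenyl for 3-hydroxyphenyl gives a 1.2-fold higher number from compound 2 to compound 4 (0.07 log units; within the scatter). With the 4-chlorophenyl and pyridin-3-yl groups held constant, the two hydroxyphenyl isomers therefore cannot be told apart in this assay, whereas the earlier step concerned only the pyridin-3-yl place. No supporting data are available to explain this result.

On these data alone, it remains open whether the same holds when thiophen-2-yl replaces pyridin-3-yl. The compounds shown also leave open what an unsubstituted phenyl, a methoxy group, an amine or a carboxylic acid at this position would do to the number.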